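Swapping Chloro for Ethyl on a Dopamine Receptor Agonist

This account rests on a few compounds, and the source may have more. Where it says the series, first, only, none or still open, it means among the compounds named here.

Compound 1 `Cc1cccc(Cl)c1NC(=O)CN1CCC(c2ccccn2)CC1` is the more potent of two measured compounds in a functional assay on HEK293 cells for agonist activity at D(4) dopamine receptor (Homo sapiens), read by FLIPR (on this read-out lower numbers stand for an effect already at smaller amounts and higher numbers for an effect only at larger amounts of compound), where compound 1 gives 60 nM. The other measured compound, compound 2 `O=C(CN1CCC(c2cccc[n+]2[O-])CC1)NC1CCCCC1`, gives 294 nM in this assay, a gap beyond the usual scatter and so a clearly higher number. Compound 3 `CCc1cccc(C)c1NC(=O)CN1CCC(c2ccccn2)CC1` has not yet been measured. It differs from compound 1 in a single place: ethyl in place of chloro on an aromatic carbon. No pair of measured compounds differs in just this way, so there is no direct precedent among the numbers shown for how such a swap plays out. The step from compound 1 to compound 3 is expected to be small, at most slightly toward a higher number, and may well stay within the scatter: a 1.5-fold higher number from compound 1 to compound 3 (0.18 log units; within the scatter). On that basis compound 3 is estimated to give 90 nM in this assay, with a range from 35 nM to 250 nM.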

Compound 3, half-maximal effective concentration: 111 nM
Beside the measured number, compound 3's estimate is 1.2-fold (0.09 log units) below it; the range from low to high includes it.
By their numbers in this assay, from the lowest: compounds 1 and 3 (each within the scatter of the next); then compound 2.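

In this assay, going by these compounds alone, the swap of chloro for ethyl, on an aromatic carbon ortho to a large group, gives a 1.9-fold higher number from compound 1 to compound 3 (0.27 log units; within the scatter) and offers the first direct reading of this position. The two compounds cannot be told apart on this number, so here a single chlorine atom can give way to a group of 2 carbon atoms with no clear shift, at least for this one pair. Nothing available explains this result.

As far as these compounds go, whether this position would accept a longer chain such as propyl or butyl, or a group of another kind such as an amine, a methoxy group or a carboxylic acid, remains open. One pair also cannot show whether the same swap would play out alike on a different core.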